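The source may hold more compounds than are shown below. What is called first, only, known or untested is meant among the compounds shown, and "the series" means these compounds.

Compound 1 `Nc1nn2c(O)cc(-c3ccccc3F)nc2c1[N+](=O)[O-]` gives 66.5 ug/mL in an ADME assay (Homo sapiens) for cytotoxicity (a lower number here means that less compound is tolerated, a higher number that more compound is tolerated), and is the only one of the three measured compounds that returns a number rather than a limit. Compound 2 `Nc1nn2c(O)cc(CCl)nc2c1[N+](=O)[O-]` gives > 50 ug/mL in this assay, which is a limit of the assay and not a number. Compound 3 `Nc1nn2c(O)cc(CNNCCO)nc2c1[N+](=O)[O-]` gives > 50 ug/mL in this assay, again a limit. Because of the limit of > 50 ug/mL in this assay, at which 2 of the 3 values shown sit, the steps a step that the limit leaves unreadable from compound 1 to compound 2, a step that the limit leaves unreadable from compound 1 to compound 3 and a step that the two limits leave unreadable from compound 2 to compound 3 cannot be sized.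

Compound 4 `Nc1nn2c(O)cc(CNNC(N)S)nc2c1[N+](=O)[O-]` has not yet been measured. It differs from compound 1 in that ((((amino(sulfanyl)methyl)amino)amino)methyl in place of 2-fluorophenyl on an aromatic carbon). For the measured compounds named here, compounds 2 and 3 also lack the 2-fluorophenyl of compound 1 and both sit at the limit; none of the measured steps is readable, so no step beyond the scatter is expected from compound 1 to compound 4 in this assay. Compound 4 is therefore expected to give 70 ug/mL in this assay, with a range of 35 ug/mL to 150 ug/mL. The step of a 1.1-fold higher number from compound 1 to compound 4 (0.02 log units; within the scatter) is estimated to lie within the scatter, and a limit rather than a number is thought likely.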

Compound 4, half-maximal cytotoxic concentration: > 50 ug/mL
Compound 4 ended at the assay's limit (the forecaster's own chance of this, stated with the estimate: 60%); the middle value lies beyond the limit too.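

Compound 4 gives > 50 ug/mL in this assay, a limit and not a number. No step to compound 4 from compound 1, compound 2 or compound 3 can be read, for this reason: the limit of > 50 ug/mL in this assay, at which 3 of the 4 values shown sit.

The compounds shown leave open whether replacing the 2-fluorophenyl of compound 1 changes the tolerated concentration at all.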